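Methoxy in place of fluoro on compound 1

The compounds below may be only part of what the source reports. "The series", "measured", "known", "first", "only" and "open" are said of these compounds alone.

Values from a functional assay on HCC70 cells (Homo sapiens) for antiproliferative activity, read by crystal violet staining, with a stated time of 96 h (a higher number here means that more compound is needed for the effect, a lower number that less compound is needed), follow.
- compound 1 (`O[C@@H]1[C@@H](O)[C@H](Oc2ccc3ccccc3c2)OC[C@H]1F`) gives (37 uM)
- compound 2 (`CO[C@H]1[C@H](Oc2ccc3ccccc3c2)OC[C@@H](O)[C@@H]1O`) gives (127 uM)

Compound 1 has the lower number of the two, and the gap to compound 2 lies beyond the scatter. Compound 3 (`CO[C@@H]1CO[C@@H](Oc2ccc3ccccc3c2)[C@H](O)[C@H]1O`) carries methoxy in place of fluoro on a saturated ring carbon. For the measured compounds named here, no measured step isolates this change. Going by the values given here, the only guide is compound 2 (127 uM), which also bears a methoxy, though elsewhere on the core. A rise is therefore expected in this assay, estimated as a step of a 2.4-fold higher number from compound 1 to compound 3 (0.39 log units; beyond the scatter) and beyond the scatter. For compound 3 the expected value is 90 uM (estimated range 35 uM to 230 uM).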

Compound 3, concentration for half-maximal effect: 135 uM
For compound 3 the middle estimate is 1.5-fold (0.18 log units) below the measured one; the range from low to high includes it.
By their numbers in this assay, from the lowest: compound 1; then compounds 2 and 3 (each within the scatter of the next).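

With a 3.6-fold higher number from compound 1 to compound 3 (0.56 log units; beyond the scatter) in this assay the change from fluoro to methoxy on this saturated ring carbon has its first direct measure, which compound 2 alone could not give. At this position the lower number stays with fluoro, and methoxy does not match it in this series. Nothing available bears on the reason for this step.

Going by these compounds, whether an amine or an ethoxy group on this ring carbon would stay near compound 1 or near compound 3 remains open.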